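Sulfonyl aryl variation on a shared core

This account rests on a few compounds, and the source may have more. Where it says the series, first, only, none or still open, it means among the compounds named here.

Measured so far:
compound 1 `COc1ccc(-c2cc(=O)c3c(OC)cc(OC)cc3n2S(=O)(=O)c2ccc([N+](=O)[O-])cc2)cc1` gives > 29300 nM, a limit of the assay
compound 2 `COc1ccc(-c2cc(=O)c3c(OC)cc(OC)cc3n2S(=O)(=O)c2c(C(C)C)cc(C(C)C)cc2C(C)C)cc1` gives > 341000 nM, a limit of the assay

Among the compounds with values here, compound 1 stands at a limit in a functional assay on HepG2 cells (Homo sapiens) for antiproliferative activity, with a stated time of 72 h (a lower number here means that less compound is needed, a higher number that more compound is needed for the effect), not at a number, and the only other reading is a limit too (the limit of > 29300 nM in this assay, at which 1 of the 2 values shown sits). Compound 3 `COc1ccc(-c2cc(=O)c3c(OC)cc(OC)cc3n2S(=O)(=O)c2ccc(OC)cc2)cc1` differs from compound 1 by methoxy in place of nitro on an aromatic carbon. Within the data shown here, no step between measured compounds is at hand; with both readings at limits, the expected step that the limit leaves unreadable from compound 1 to compound 3 is none beyond the scatter, and compound 3 is expected to return a limit again. Compound 3 is estimated at 40000 nM, with a range from 15000 nM to 150000 nM.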

Compound 3, half-maximal effective concentration: > 82700 nM
Compound 3 was reported as a limit (the forecaster's own chance of this, stated with the estimate: 75%); middle value at least 2.0-fold (0.31 log units) from the limit.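

Within the data shown here, compound 1 and compound 3 both stand at limits of the assay in this assay; no step between them can be read. The compounds shown leave open whether any sulfonyl aryl variation on the shared core gives a numerical reading in this assay, and how methoxy and nitro compare.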